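The source may hold more compounds than are shown below. What is called first, only, known or untested is meant among the compounds shown, and "the series" means these compounds.

Two compounds carry the shared core of compound 1 `O=C1Nc2ccc(Cl)cc2/C1=N/NC(=S)Nc1ccc(Cl)cc1`. In a functional assay on L1210 cells (Mus musculus), with a stated time of 48 h (a higher number here means a weaker inhibitor, a lower number a stronger inhibitor), compound 1 gives 108000 nM. Compound 2 `Cc1ccc(CN2C(=O)/C(=N\NC(=S)Nc3ccc(Cl)cc3)c3cc(Cl)ccc32)cc1`, which bears a 4-methylbenzyl group on the ring nitrogen, gives 9800 nM, the lowest of the two numbers; the step of an 11-fold lower number from compound 1 to compound 2 (1.04 log units; beyond the scatter) is the only measured one. Compound 3 `O=C1/C(=N\NC(=S)Nc2ccc(Cl)cc2)c2cc(Cl)ccc2N1Cc1ccc(Cl)cc1` differs from compound 2 by a single swap: chloro in place of methyl on an aromatic carbon. Among the measured compounds shown here, no measured step touches this position, since the one known step concerns the benzyl group as a whole rather than the substituent on its ring. The expectation for compound 3 therefore rests on the value of compound 2 alone, and the step of a 1.2-fold lower number from compound 2 to compound 3 (0.09 log units; within the scatter) is estimated to stay within the scatter. Compound 3 is thus expected to give about 8000 nM, with a range from 3000 nM to 25000 nM.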

Compound 3, half-maximal inhibitory concentration: 124000 nM
Beside the measured number, compound 3's estimate is 16-fold (1.19 log units) below it; the whole stated range lies below it.
By their numbers in this assay, from the lowest: compound 2; then compounds 1 and 3 (each within the scatter of the next).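

In this assay, a single swap on the outer ring of the benzyl group, with one heavy atom leaving and one entering, gives a 13-fold higher number from compound 2 to compound 3 (1.10 log units; beyond the scatter) and so removes the advantage compound 2 held. The earlier step of an 11-fold lower number from compound 1 to compound 2 (1.04 log units; beyond the scatter) therefore cannot be credited to any benzyl group on the ring nitrogen: 4-chlorobenzyl in place of the hydrogen gives only a 1.1-fold higher number from compound 1 to compound 3 (0.06 log units; within the scatter) and stays within the scatter, so the benefit depends on what sits at the end of the benzyl group. Nothing available here explains why methyl and chloro part so sharply at this position.

The compounds shown leave open where a plain benzyl group without any substituent would fall. As far as these compounds go, it also remains open whether an ethyl or a methoxy group at this position would keep the low number of compound 2.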